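Swapping a Pyrrole for Methoxyphenyl: A Weak Inhibitor Expected

The compounds below may be only part of what the source reports. "The series", "measured", "known", "first", "only" and "open" are said of these compounds alone.

Compound 1 `N#C/C(=C\c1c(F)c(F)c(F)c(F)c1F)C(=O)c1ccc[nH]1`: 25000 nM
Compound 2 `N#C/C(=C\c1ccc[nH]1)C(=O)NCc1ccc(Cl)c(Cl)c1`: > 50000 nM

In a functional assay on MIA cells (Homo sapiens) for inhibition, read by MTT assay, with a stated time of 72 h (on this read-out lower numbers stand for stronger inhibition of growth and higher numbers for weaker inhibition of growth), compound 1 gives 25000 nM. Compound 2 reaches only a limit of this assay, > 50000 nM, so its true value is not known (the limit of > 50000 nM in this assay, at which 1 of the 2 values shown sits). Compound 3 `COc1ccc(/C=C(\C#N)C(=O)NCc2ccc(Cl)c(Cl)c2)cc1` differs from compound 2 in one place: 4-methoxyphenyl in place of 1H-pyrrol-2-yl on a double-bonded chain carbon bound to a double-bonded chain carbon. Within the data shown here, no measured pair shows what this change does, and with compound 2 standing at a limit no step can be read from it. Compound 3 is therefore expected to stay weak, near the limit, with an estimated step of a number no higher from compound 2 to compound 3 (the limit leaves the size open). For compound 3 the estimate is 50000 nM, between 15000 nM and 200000 nM.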

Compound 3, concentration for 50% growth inhibition: 79000 nM
The estimate for compound 3 lay 1.6-fold (0.20 log units) below the measured number, and the stated range covers the measured number.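

No step from compound 2 to compound 3 can be read in this assay, because compound 2 stands at a limit: the limit of > 50000 nM in this assay, at which 1 of the 3 values shown sits.

The compounds shown leave open whether 4-methoxyphenyl in place of 1H-pyrrol-2-yl strengthens or weakens growth inhibition, and by how much.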